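Half-life of an ester and its acid

This account rests on a few compounds, and the source may have more. Where it says the series, first, only, none or still open, it means among the compounds named here.

Measured in an ADME assay on a cell-free system (plasma, Homo sapiens) for metabolic stability, read by LC-MS (a lower number here means that the compound disappears faster, a higher number that the compound lasts longer), as half-life:
- Compound 1 `NCc1ccc(C(=O)Nc2ccncc2F)cc1-c1cccc(C(=O)OCC2CCCO2)c1` gives < 0.0834 h as a limit
- Compound 2 `NCc1ccc(C(=O)Nc2ccncc2F)cc1-c1cccc(C(=O)OCCO)c1` gives 1.35 h as a number
- Compound 3 `NCc1ccc(C(=O)Nc2ccncc2F)cc1-c1cccc(C(=O)O)c1` gives > 2 h as a limit

For compound 3 the figure > 2 h is a limit and not a number. Compound 4 `NCc1ccc(C(=O)Nc2ccncc2F)cc1-c1cccc(C(=O)OCC2CCCC2)c1` differs from compound 3 thus: cyclopentylmethyl in place of hydrogen on an oxygen next to a carbonyl group and so carboxy becomes cyclopentylmethoxycarbonyl. The closest guide is an at least 23-fold higher number from compound 1 to compound 3 (1.37 log units; beyond the scatter) with (oxolan-2-yl)methyl leaving, and an at least 16-fold higher number from compound 1 to compound 2 (1.20 log units; beyond the scatter) points the same way. Compound 2 goes against any simple rule for these esters, as an at least 1.4-fold higher number from compound 2 to compound 3 (0.17 log units; that floor lies within the scatter) shows. The ring-bearing group of compound 1 is the nearer match for cyclopentylmethyl, so a large fall is expected in this assay as the reverse of that step. The estimated step is an at least 20-fold lower number from compound 3 to compound 4 (1.30 log units; beyond the scatter) as expected here. Compound 4 is expected at 0.1 h within an estimated range of 0.04 h to 0.6 h for this half-life.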

Compound 4, half-life: 0.283 h
Estimate against measurement, compound 4: 2.8-fold (0.45 log units) below; measured number inside the range.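

In this assay, cyclopentylmethyl on the oxygen next to the carbonyl group gives an at least 7.0-fold lower number from compound 3 to compound 4 (0.84 log units; beyond the scatter), so this ester lasts a shorter time than the acid. Cyclopentyl in place of oxolan-2-yl gives an at least 3.3-fold higher number from compound 1 to compound 4 (0.53 log units; beyond the scatter), which shows that the two ring-bearing esters do not behave alike. Cyclopentyl in place of hydroxymethyl gives a 4.8-fold lower number from compound 2 to compound 4 (0.68 log units; beyond the scatter), placing this ester between the two earlier ones. The compounds shown leave open how an ethyl chain or a longer open chain would behave on this oxygen. They also do not show whether compound 4 disappears by turning into compound 3.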